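The compounds below may be only part of what the source reports. "The series", "measured", "known", "first", "only" and "open" are said of these compounds alone.

Measured in a functional assay on PC-3 cells (Homo sapiens) for inhibition, read by sulforhodamine B assay, with a stated time of 48 h, tested at 50 uM; on this read-out higher numbers stand for more inhibition of growth at the one concentration tested and lower numbers for less inhibition of growth:
- compound 1 `COc1cc(/C=C/C(=O)/C=C/c2cccs2)ccc1OCc1cn(CCOc2cc(=O)oc3ccccc23)nn1`: 12%
- compound 2 `COc1ccc(/C=C/C(=O)/C=C/c2ccc(OCc3cn(CCOc4cc(=O)oc5ccccc45)nn3)c(OC)c2)cc1OC`: 19%
- compound 3 `COc1cc(/C=C/C(=O)/C=C/c2ccccc2)ccc1OCc1cn(CCOc2cc(=O)oc3ccccc23)nn1`: 10%

For the measured compounds named here, compound 3, at 10%, lies within the scatter of the other two compounds, so the series so far shows no separation in this assay. The next compound is compound 4 `COc1ccc(/C=C/C(=O)/C=C/c2ccc(OCc3cn(CCOc4cc(=O)oc5ccccc45)nn3)c(OC)c2)cc1`, which differs from compound 3 by methoxy in place of hydrogen on an aromatic carbon. This is methoxy in place of hydrogen on an aromatic carbon, turning phenyl into 4-methoxyphenyl.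

Going by the values given here, no measured step makes exactly this change. The closest is a number 9 percentage points lower from compound 2 to compound 3 (within the scatter), where phenyl replaces 3,4-dimethoxyphenyl, and compound 4 keeps part of the methoxy substitution of compound 2. The two steps from compound 1, which replace thiophen-2-yl, are a number 7 percentage points higher from compound 1 to compound 2 (within the scatter) and a number 2 percentage points lower from compound 1 to compound 3 (within the scatter). All three changes to this group stay within the scatter, so a clear effect from a single methoxy is not expected. The step expected is a number 4 percentage points higher from compound 3 to compound 4 (within the scatter), which is no step beyond the scatter. For compound 4 the estimated value is 14%, with an expected range from 6% to 24%.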

Compound 4, percent growth inhibition at one concentration: 15%
For compound 4 the middle estimate is 1 percentage points below the measured one; the range from low to high includes it.
By their numbers in this assay, from the lowest: compounds 3, 1, 4 and 2 (each within the scatter of the next).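

In this assay a single methoxy on this aryl group can now be read directly: adding it to the phenyl of compound 3 gives a number 5 percentage points higher from compound 3 to compound 4 (within the scatter) and removing the other methoxy of the 3,4-dimethoxyphenyl group gives a number 4 percentage points lower from compound 2 to compound 4 (within the scatter) so neither the first nor the second methoxy separates from the scatter on this evidence. Exchanging thiophen-2-yl for 4-methoxyphenyl gives a number 3 percentage points higher from compound 1 to compound 4 (within the scatter) which places a fourth aryl group on this end of the chain and adds one more step that does not rise above the scatter, so phenyl, 4-methoxyphenyl, 3,4-dimethoxyphenyl and thiophen-2-yl cannot be told apart here. No measurement is available that could explain these small steps.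

Only aryl groups at this end of the chain are shown, so it remains open whether an amine or a carboxylic acid on the same aromatic carbon, or butoxy as a longer chain in place of methoxy, would give a step beyond the scatter. Also open, as far as these compounds go, is whether a change elsewhere on the shared core would separate these compounds.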